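Swapping One Ring Centre in the Oxane Amide Series

The source may hold more compounds than are shown below. What is called first, only, known or untested is meant among the compounds shown, and "the series" means these compounds.

Of the compounds shown here, three share one core and have been tested in an assay on CHO cells for displacement of a labelled ligand from histamine receptor H3 (Macaca mulatta); a lower number here means a stronger inhibitor, a higher number a weaker inhibitor. Compound 1, `Cc1cc(N2CC[C@H](N3CCC[C@@H]3C)C2)ccc1NC(=O)C1C(C)(C)C1(C)C`, gives 0.55 nM. Compound 2, `Cc1cc(N2CCC(N3CCCC3C)C2)ccc1NC(=O)C1CCOCC1`, gives 6.8 nM, and compound 3, `Cc1cc(N2CC[C@@H](N3CCC[C@@H]3C)C2)ccc1NC(=O)C1CCOCC1`, gives 3.9 nM. Compound 3 thus sits in the middle of the measured range, with a 1.7-fold lower number from compound 2 to compound 3 (0.24 log units; within the scatter); the only hint as to why rests on (the fact that one of compounds 2 and 3 is drawn with a defined configuration and the other without, at the place where they differ). Compound 4, `Cc1cc(N2CC[C@H](N3CCC[C@@H]3C)C2)ccc1NC(=O)C1CCOCC1`, now changes compound 3 only as follows: the two compounds have the same atoms and bonds and differ only in configuration as drawn: 1 of 2 stereo elements differ; a stereocentre at a saturated ring carbon is drawn R in compound 3 and S in compound 4. Among the measured compounds shown here, no measured step covers this exact change, and the one stereo step known lies within the scatter, so the expected step of a 1.3-fold lower number from compound 3 to compound 4 (0.11 log units; within the scatter) is also small, with no clear direction. Compound 4 is therefore estimated at 3 nM, between 1 nM and 9 nM.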

Compound 4, inhibition constant: 0.97 nM
Beside the measured number, compound 4's estimate is 3.1-fold (0.49 log units) above it; the whole stated range lies above it.
By their numbers in this assay, from the lowest: compounds 1 and 4 (each within the scatter of the next); then compounds 3 and 2 (each within the scatter of the next).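

The step from R to S at one saturated ring carbon is a 4.0-fold lower number from compound 3 to compound 4 (0.60 log units; beyond the scatter), and its source is plain: the fact that compounds 3 and 4 differ only in the configuration as drawn. Set against compound 2, drawn without configurations, the result is a 7.0-fold lower number from compound 2 to compound 4 (0.85 log units; beyond the scatter), so a defined arrangement can matter here even though the earlier stereo step did not show it. With that arrangement held, oxan-4-yl in place of 2,2,3,3-tetramethylcyclopropyl gives a 1.8-fold higher number from compound 1 to compound 4 (0.25 log units; within the scatter).

Going by these compounds, the second stereocentre is drawn alike in compound 3 and compound 4, so its own effect stays open. Also open, on these data alone, is how an amine in place of oxan-4-yl would fare.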